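Swapping the Ether Side Chain of Compound 2

The source may report more compounds than this note shows. Statements on the series, on what has been measured and on what is new or still open speak of the compounds shown alone.

Measured so far in a functional assay on HEK293 cells for agonist activity at G-protein coupled receptor 39 (Homo sapiens), read by scintillation proximity assay and inositol phosphate accumulation, with a stated time of 75 min, in the presence of a further agent that is not named here; on this read-out lower numbers stand for an effect already at smaller amounts and higher numbers for an effect only at larger amounts of compound:
compound 1, `CCC(C(=O)NC1CC(=O)Nc2c1c(C)nn2-c1ncnc2nc[nH]c12)c1ccccc1`: 5 nM
compound 2, `Cc1cc(C)n(CCOC2CC(=O)Nc3c2c(C)nn3-c2ncnc3nc[nH]c23)n1`: 16 nM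
compound 3, `CC(C)(C)c1cc(C(=O)N/N=C/c2ccc(O)cc2O)[nH]n1`: 240 nM

Compound 2 holds the second highest of the three numbers in this assay. Its nearest neighbour is compound 1, whose lower number lies beyond the scatter; its furthest is compound 3, whose higher number also lies beyond the scatter. No two of these compounds differ in only one place, so no single-change step is available as a direct precedent.

Compound 4, `Cc1nn(-c2ncnc3nc[nH]c23)c2c1C(OCc1ccc(F)cc1)CC(=O)N2`, has not yet been measured in this assay. It differs from compound 2 in one place: 4-fluorophenyl in place of (3,5-dimethyl-1H-pyrazol-1-yl)methyl on a saturated chain carbon bound to an oxygen on a saturated carbon. The shared core is untouched, and only the group beyond the oxygen on the saturated chain carbon changes.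

Compound 1 carries a six-membered carbon ring on its side chain and gives the lowest number of the three, which is the only hint here. Compound 4 is therefore expected to land near compound 2, at 10 nM, with a range from 3 nM to 40 nM. The step from compound 2 to compound 4 is expected to be a 1.6-fold lower number from compound 2 to compound 4 (0.20 log units; within the scatter), no more than the usual scatter, leaning if anything toward a lower number.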

Compound 4, half-maximal effective concentration: 1 nM
For compound 4 the middle estimate is 10-fold (1.00 log units) above the measured one; measured number outside the range, below it.
By their numbers in this assay, from the lowest: compound 4; then compound 1; then compound 2; then compound 3.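

In this assay, the group beyond the oxygen proves decisive: 4-fluorophenyl in place of (3,5-dimethyl-1H-pyrazol-1-yl)methyl gives a 16-fold lower number from compound 2 to compound 4 (1.20 log units; beyond the scatter), so this position responds strongly to the change while the shared core stays the same. The entering group has a six-membered aromatic ring of carbon only and 0 hydrogen-bond acceptors, whereas the leaving group has a five-membered aromatic ring with 2 hetero atoms and 2 hydrogen-bond acceptors, so those acceptors are not needed for a low number here. The data shown offer nothing that explains the size of this step.

A plain benzyl group, or chlorine or methoxy in the place of the fluorine, would show how much of the step depends on the fluorine itself. Going by these compounds, it also remains open how a longer chain between the oxygen and the aromatic ring would read out.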